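The compounds below may be only part of what the source reports. "The series", "measured", "known", "first", "only" and "open" are said of these compounds alone.

Measured compounds in an assay on isolated protein for inhibition of protein kinase C theta type (Homo sapiens), read by TR-FRET, with a stated time of 2 h; a higher number here means a weaker inhibitor, a lower number a stronger inhibitor:
compound 1 `N#Cc1cnc(NCc2cnccc2C(F)(F)F)cc1N[C@H]1CC[C@@H](O)CC1` — 100 nM
compound 2 `N#Cc1cnc(NCc2cnccc2C(F)(F)F)cc1NC[C@H]1CC[C@H](O)CC1` — 50 nM
compound 3 `N#Cc1cnc(NCc2cnccc2C(F)(F)F)cc1NCC1CCOCC1` — 400 nM

Compound 3 stands with the highest number of the three; its gaps to both others are beyond the scatter, with compound 1 the nearer and compound 2 the further.

The next compound, compound 4 `CC1(C)C[C@H](Nc2cc(NCc3cnccc3C(F)(F)F)ncc2C#N)CC[C@@H]1O`, differs from compound 3 by 4-hydroxy-3,3-dimethylcyclohexyl in place of (oxan-4-yl)methyl on a nitrogen on an aromatic ring. The measured step that bears on this is a 4.0-fold higher number from compound 1 to compound 3 (0.60 log units; beyond the scatter), which runs in the opposite direction to the present change: putting a hydroxycyclohexyl group back directly on that nitrogen should retrace most of it. Within the data shown here, the two methyl groups entering with the new ring have no counterpart among the measured compounds, so no step can be assigned to them. The hydroxycyclohexyl motif is shared by compounds 1 and 2, whose numbers lie within the scatter of each other, as a 2.0-fold lower number from compound 1 to compound 2 (0.30 log units; within the scatter) shows, so the exact tether matters little here.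

For compound 4 the expected step is a 4.0-fold lower number from compound 3 to compound 4 (0.60 log units; beyond the scatter), downward. Compound 4 is thus estimated at 100 nM, with a range from 30 nM to 300 nM.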

Compound 4, half-maximal inhibitory concentration: 7 nM
Beside the measured number, compound 4's estimate is 14-fold (1.15 log units) above it; measured number below the stated range.
By their numbers in this assay, from the lowest: compound 4; then compounds 2 and 1 (each within the scatter of the next); then compound 3.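

In this assay, among these compounds, the closest comparison is a 14-fold lower number from compound 1 to compound 4 (1.15 log units; beyond the scatter), where the groups on the nitrogen differ only by the two methyl groups of 4-hydroxy-3,3-dimethylcyclohexyl, so this substitution on the hydroxycyclohexyl ring carries a large gain that the earlier compounds gave no sign of. The other comparisons, a 7.1-fold lower number from compound 2 to compound 4 (0.85 log units; beyond the scatter) and a 57-fold lower number from compound 3 to compound 4 (1.76 log units; beyond the scatter), are also beyond the scatter, which makes compound 4 the strongest inhibitor of the four. Nothing available explains this gain.

From the compounds shown here alone, it remains open whether a single methyl group on the ring gives part of the gain or whether both are needed. Also unsettled is whether the gain survives when the hydroxy group gives way to a methoxy group or an amine, or when the two methyl groups give way to ethyl groups.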